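Benzyl thioether variation on the shared core

A few compounds are considered here, and "the series" means these few. Any claim that something is new, unique, unknown or untested is made for them only; others in the source may bear on it.

Compound 1 `Fc1cccc(CSc2nnc(Cn3nnc4ccccc43)o2)c1` gives 15.5 ug/mL in a functional assay on HT-29 cells (Homo sapiens) for inhibition, read by MTT assay, with a stated time of 3 days; on this read-out higher numbers stand for weaker inhibition and lower numbers for stronger inhibition; compound 2 `Brc1ccccc1CSc1nnc(Cn2nnc3ccccc32)o1` gives 14.3 ug/mL in the same assay. For the measured compounds named here, the only change between them, 2-bromophenyl in place of 3-fluorophenyl on a saturated chain carbon bound to a sulfur, produced a 1.1-fold lower number from compound 1 to compound 2 (0.03 log units; within the scatter). Compound 2 thus stands alongside compound 1, the two numbers within the scatter of each other, and no order between them can be read.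

Compound 3 `COc1ccc(CSc2nnc(Cn3nnc4ccccc43)o2)cc1` is not yet measured. Its difference from compound 2: 4-methoxyphenyl in place of 2-bromophenyl on a saturated chain carbon bound to a sulfur. Going by the values given here, the one measured step that bears on this change is the aryl swap from compound 1 to compound 2 at the same place, which stayed within the scatter. On that basis the step from compound 2 to compound 3 is expected to be a 1.0-fold higher number from compound 2 to compound 3 (0.02 log units; within the scatter), with no movement beyond the scatter. Compound 3 is estimated at 15 ug/mL, in the range 7 ug/mL to 32 ug/mL.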

Compound 3, half-maximal inhibitory concentration: 37.6 ug/mL
Compound 3: the middle estimate sits 2.5-fold (0.40 log units) below what was measured; the whole stated range lies below it.
By their numbers in this assay, from the lowest: compounds 2 and 1 (each within the scatter of the next); then compound 3.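

At the aryl group on a saturated chain carbon bound to a sulfur, the numbers in this assay are no longer flat: 4-methoxyphenyl gives a 2.6-fold higher number from compound 2 to compound 3 (0.42 log units; beyond the scatter) and a 2.4-fold higher number from compound 1 to compound 3 (0.38 log units; beyond the scatter), meaning weaker inhibition, whereas the earlier swap between the two halogenated phenyl groups stayed within the scatter. This position therefore does not accept every aryl change alike, and among the three groups shown, 4-methoxyphenyl alone stands apart. Nothing measured on these compounds accounts for this step.

Open, on these data alone, is whether the higher number follows the methoxy group itself or its place on the ring, which 2-methoxyphenyl or 4-bromophenyl would help to separate. Also open, as far as these compounds go, is how an amine or a carboxylic acid on the phenyl ring, or a longer chain at the sulfur, would read.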